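From compound 3 to compound 4: one group exchanged

The source may report more compounds than this note shows. Statements on the series, on what has been measured and on what is new or still open speak of the compounds shown alone.

Measured in a functional assay on Hs 683 cells (Homo sapiens) for inhibition, read by MTT assay, with a stated time of 72 h (a lower number here means a stronger inhibitor of growth, a higher number a weaker inhibitor of growth), are three compounds.
- Compound 1 `Cc1cn([C@@H]2O[C@H](CO[Si](C)(C)C(C)(C)C)[C@@H](O)[C@H]2O)c(=O)[nH]c1=O` gives 77000 nM
- Compound 2 `Cc1cn([C@@H]2O[C@H](CO[Si](c3ccccc3)(c3ccccc3)C(C)(C)C)[C@@H](O)[C@H]2O)c(=O)[nH]c1=O` gives 27000 nM
- Compound 3 `CC(C)(C)[Si](OC[C@H]1O[C@@H](n2ccc(N)nc2=O)[C@H](O)[C@@H]1O)(c1ccccc1)c1ccccc1` gives 40000 nM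

Compound 3 at 40000 nM sits within the scatter of both compound 2 and compound 1. Compound 4 `CC(C)(C)[Si](OC[C@H]1O[C@@H](n2cnc3c(N)ncnc32)[C@H](O)[C@@H]1O)(c1ccccc1)c1ccccc1` differs from it in one group (a group of 10 heavy atoms (5 carbon, 5 nitrogen; one five-membered aromatic ring with 2 hetero atoms, one six-membered aromatic ring with 2 hetero atoms) in place of a group of 8 heavy atoms (4 carbon, 3 nitrogen, 1 oxygen; one six-membered aromatic ring with 2 hetero atoms), on a saturated ring carbon), on a saturated ring carbon next to the ring oxygen. Among the compounds with values here, the only measured exchange at that place (a 1.5-fold higher number from compound 2 to compound 3 (0.17 log units; within the scatter)) stayed within the scatter, so in this assay no step beyond the scatter is expected, although a five-membered aromatic ring enters that no measured compound carries. This expectation is written as an estimated step (a 1.3-fold lower number from compound 3 to compound 4 (0.12 log units; within the scatter)) within the scatter. Compound 4 is estimated at 30000 nM (expected range 14000 nM to 65000 nM).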

Compound 4, concentration for 50% growth inhibition: 46000 nM
Estimate against measurement, compound 4: 1.5-fold (0.19 log units) below; the range from low to high includes it.
By their numbers in this assay, from the lowest: compounds 2, 3, 4 and 1 (each within the scatter of the next, the first and the last beyond it).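

In this assay, the exchange on the saturated ring carbon next to the ring oxygen gives a 1.2-fold higher number from compound 3 to compound 4 (0.06 log units; within the scatter) and a 1.7-fold higher number from compound 2 to compound 4 (0.23 log units; within the scatter). A group with a five-membered aromatic ring alongside a six-membered one thus enters at this place with no step beyond the scatter, so all three groups measured there remain indistinguishable. Nothing available here accounts for this result. Going by these compounds, whether a group with no aromatic ring at that carbon, such as an amine or a carboxylic acid, would produce a step beyond the scatter remains open.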